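This account rests on a few compounds, and the source may have more. Where it says the series, first, only, none or still open, it means among the compounds named here.

Measured so far:
compound 1 `COc1ccccc1-n1nc([C@@H]2CCO[C@H](C(C)C)C2)cc1-c1ccc(Cl)cc1` — 55000 nM
compound 2 `COc1ccccc1-n1nc(C2CC(C)(C)OC(C)(C)C2)cc1-c1ccc(C)nc1` — 13000 nM
compound 3 `COc1ccccc1-n1nc(C2=CC(C)(C)OC(C)(C)C2)cc1-c1ccc(Cl)cc1` — 26000 nM

In an assay on HEK293 cells for inhibition of Voltage-dependent N-type calcium channel subunit alpha-1B (Homo sapiens), read by patch clamp, using a membrane potential dye (a higher number here means a weaker inhibitor, a lower number a stronger inhibitor), compound 1 gives 55000 nM, compound 2 gives 13000 nM and compound 3 gives 26000 nM. Compound 2 sits at the low end of these three numbers; its gap to compound 3 is within the usual scatter, its gap to compound 1 beyond it. Among the measured compounds shown here, the only single-place step among the measured compounds, a 2.1-fold lower number from compound 1 to compound 3 (0.33 log units; beyond the scatter), changes the saturated ring and not the aromatic group, so it does not speak directly to the change now in question.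

Compound 4 `COc1ccccc1-n1nc(C2CC(C)(C)OC(C)(C)C2)cc1-c1ccc(C#N)cc1` differs from compound 2 in one place: 4-cyanophenyl in place of 6-methylpyridin-3-yl on an aromatic carbon. For the measured compounds named here, no measured pair isolates such a swap of the aromatic group, so there is no step to lean on. Given that, the expectation is no step beyond the scatter, no change at the digits printed from compound 2 to compound 4 (within the scatter). Compound 4 is therefore estimated at 13000 nM, with a range from 5000 nM to 35000 nM.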

Compound 4, half-maximal inhibitory concentration: 85 nM
Beside the measured number, compound 4's estimate is 150-fold (2.18 log units) above it; measured number outside the range, below it.
By their numbers in this assay, from the lowest: compound 4; then compounds 2 and 3 (each within the scatter of the next); then compound 1.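

In this assay, the group on this aromatic carbon of the five-membered ring proves decisive: 4-cyanophenyl in place of 6-methylpyridin-3-yl gives a 150-fold lower number from compound 2 to compound 4 (2.18 log units; beyond the scatter). Among the compounds shown here, the only earlier step, a 2.1-fold lower number from compound 1 to compound 3 (0.33 log units; beyond the scatter), changed the saturated ring and was far smaller, so the earlier compounds gave no sign that so much could turn on this aromatic group. No measurement shown gives a reason for this drop.

The swap exchanges a ring with a hetero atom for a ring of carbon only and also exchanges methyl for nitrile, so the compounds shown cannot say which of these differences carries the effect. Comparing 4-methylphenyl and 6-cyanopyridin-3-yl at the same place, on the core of compound 2, would pull the two apart.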